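The source may report more compounds than this note shows. Statements on the series, on what has been measured and on what is new or still open speak of the compounds shown alone.

The measured compounds are compound 1 `O=C(CCCCCc1ccccc1)N[C@H]1CCOC1=O`, compound 2 `O=C(CCCCCCCCc1ccccc1)N[C@H]1CCOC1=O` and compound 3 `O=C(CCCCCCCCCCc1ccccc1)CC(=O)N[C@H]1CCOC1=O`. In a functional assay on NCI-H630 cells (Homo sapiens) for cytotoxicity, read by sulforhodamine B assay, with a stated time of 5 days (a higher number here means a weaker inhibitor, a lower number a stronger inhibitor), compound 1 gives > 100000 nM, which is a limit of the assay and not a number. Compound 2 likewise gives > 100000 nM, again a limit rather than a number. Among the compounds with values here, compound 3 gives 14000 nM, the only number among the three; the other two rest at the limit of > 100000 nM in this assay, at which 2 of the 3 values shown sit. Compound 4 `O=C(CCCCCCCc1ccccc1)CC(=O)N[C@H]1CCOC1=O` is not yet measured and differs from compound 3 by phenyl in place of 3-phenylpropyl on a saturated chain carbon, seven bonds along the chain from a carbonyl carbon. Within the data shown here, no step between measured compounds is available to guide this change, and the account expects it to weaken inhibition beyond the usual scatter, possibly as far as the limit. Compound 4 is estimated at 40000 nM, between 14000 nM and 100000 nM. The expected step is a 2.9-fold higher number from compound 3 to compound 4 (0.46 log units; beyond the scatter).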

Compound 4, half-maximal inhibitory concentration: 10000 nM
The estimate for compound 4 lay 4.0-fold (0.60 log units) above the measured number; the whole stated range lies above it.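

In this assay, phenyl in place of 3-phenylpropyl on a saturated chain carbon, seven bonds along the chain from a carbonyl carbon, gives a 1.4-fold lower number from compound 3 to compound 4 (0.15 log units; within the scatter). Within the data shown here, this position therefore takes either group with no difference that can be told from the scatter, a point the earlier compounds, with no step between them, could not show. Nothing shown gives a cause for this result. The compounds shown leave open whether a much longer chain, an amine or a carboxylic acid at this place would keep the number.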